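A few compounds are considered here, and "the series" means these few. Any claim that something is new, unique, unknown or untested is made for them only; others in the source may bear on it.

Measured so far in a functional assay on HeLa cells (Homo sapiens) for antiproliferative activity, read by MTT assay, with a stated time of 72 h; a higher number here means a weaker inhibitor, a lower number a stronger inhibitor:

Compound 1 `O=C(Nc1ccc(Cl)c(-c2nnc3c(Cl)cccn23)c1)c1ccccn1` — compound 1 gives 75500 nM.
Compound 2 `O=C(Nc1ccc(Cl)c(-c2nnc3c(Cl)cccn23)c1)c1ccc(Cl)cc1` — compound 2 gives > 100000 nM, which is a limit of this assay and not a number.
Compound 3 `O=C(Nc1ccc(Cl)c(-c2nnc3c(Cl)cccn23)c1)c1c(F)cccc1Cl` — compound 3 gives > 100000 nM, again a limit of this assay and not a number.

Compound 3 therefore stands only at a limit; no number is known for it, and the limit of > 100000 nM in this assay, at which 2 of the 3 values shown sit, marks the same position for a second member of the series. Among the measured compounds shown here, the steps that can be read are an at least 1.3-fold higher number from compound 1 to compound 2 (0.12 log units; that floor lies within the scatter) and an at least 1.3-fold higher number from compound 1 to compound 3 (0.12 log units; that floor lies within the scatter); both have a floor that lies within the scatter, so neither shows a change that can be called real, only that the pyridin-2-yl compound 1 is the one member with a measured number. The step that the two limits leave unreadable from compound 2 to compound 3 cannot be read at all, since both ends are limits.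

The next compound is compound 4 `O=C(Nc1ccc(Cl)c(-c2nnc3c(Cl)cccn23)c1)c1ccccc1`. The change from compound 3 is phenyl in place of 2-chloro-6-fluorophenyl on a carbonyl carbon. Every measured member of this series is a weak inhibitor in this assay, and the two nearest analogues of compound 4 sit at the limit, so no step beyond the scatter is expected; compound 4 is expected to give 110000 nM, with a range from 40000 nM to 300000 nM, which means an expected step that the limit leaves unreadable from compound 3 to compound 4 and most likely only a further limit.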

Compound 4, half-maximal inhibitory concentration: > 100000 nM
Compound 4 was reported as a limit; the forecaster's own chance of this, stated with the estimate: 65%; the middle value does not contradict the limit.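

In this assay compound 4 joins compound 2 and compound 3 at a limit, so a plain phenyl on the carbonyl carbon, with no halogen on the ring, is not told apart from 4-chlorophenyl or 2-chloro-6-fluorophenyl. The steps among these three compounds cannot be read, and the one readable step, an at least 1.3-fold higher number from compound 1 to compound 4 (0.12 log units; that floor lies within the scatter), has a floor within the scatter, so it shows no real change for phenyl in place of pyridin-2-yl. Most of the series now sits at a single mark: the limit of > 100000 nM in this assay, at which 3 of the 4 values shown sit.

On these data alone, how the compounds at the limit stand relative to one another stays open, since none of them has a number. Also open, as far as these compounds go, is whether a dimethylamine or a carboxylic acid on the ring attached to the carbonyl carbon would give a number clearly lower than that of compound 1 , which gives 75500 nM in this assay.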